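The source may hold more compounds than are shown below. What is called first, only, known or untested is meant among the compounds shown, and "the series" means these compounds.

Working notes on the series

Compound 1 `CCCCn1ccc(-c2ccc(Oc3ccnc(C)c3)cc2)c(C#N)c1=O` is the reference point. In a functional assay on CHO cells for positive allosteric modulation of metabotropic glutamate receptor 2 (Homo sapiens), read by scintillation counting and GTPgammaS binding, with a stated time of 30 min (a lower number here means that less compound is needed, a higher number that more compound is needed for the effect), compound 1 gives 398 nM. Among the compounds with values here, compound 2 `Cc1cc(Oc2ccc(-c3ccn(CC4CC4)c(=O)c3C#N)cc2)ccn1` carries the change (cyclopropyl in place of propyl on a saturated chain carbon bound to an aromatic nitrogen); in this assay compound 2 gives 832 nM, and the step of a 2.1-fold higher number from compound 1 to compound 2 (0.32 log units; beyond the scatter) is the one direct reading of this change in the set.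

Compound 3 `CCCCn1ccc(-c2ccc(Oc3ccc(C)nc3C)c(Cl)c2)c(C#N)c1=O` rests on a different core; the difference between the two cores is not broken down here. In this assay compound 3 gives 30 nM, the lowest number among the three measured compounds, with both gaps to compound 1 and compound 2 beyond the scatter.

Compound 4 `Cc1ccc(Oc2ccc(-c3ccn(CC4CC4)c(=O)c3C#N)cc2Cl)c(C)n1` differs from compound 3 by cyclopropyl in place of propyl on a saturated chain carbon bound to an aromatic nitrogen, the same change that separates compound 1 from compound 2, at the same place. The expectation for compound 4 is a step of a 2.0-fold higher number from compound 3 to compound 4 (0.30 log units; within the scatter) in this assay, set beside the measured 2.1-fold higher number from compound 1 to compound 2 (0.32 log units; beyond the scatter) and resting on that single earlier reading on another core. Compound 4 is therefore expected at 60 nM in this assay, within 30 nM to 130 nM.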

Compound 4, half-maximal effective concentration: 64 nM
Estimate against measurement, compound 4: 1.1-fold (0.03 log units) below, and the stated range covers the measured number.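

In this assay, the new step is a 2.1-fold higher number from compound 3 to compound 4 (0.33 log units; beyond the scatter), with cyclopropyl in place of propyl on a saturated chain carbon bound to an aromatic nitrogen. Set beside the earlier reading, the change carries from one core to the other with no difference in the size of the step: the same change on two cores in this assay, a 2.1-fold higher number (0.32 log units; beyond the scatter) from compound 1 to compound 2 and a 2.1-fold higher number (0.33 log units; beyond the scatter) from compound 3 to compound 4, 1.0-fold (0.01 log units) apart, within the scatter of two such steps. This rests on two pairs in a single assay, so it shows that the step holds between the core of compound 1 and the core of compound 3, but it does not show that it would hold on any other core, and it gives no reason for the higher number.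

Only butyl and cyclopropylmethyl are shown at this place, which leaves open how a longer chain such as hexyl, or a chain ending in an amine or a carboxylic acid, would read on either core. Also open is how the differences between the two cores contribute individually, as no pair shown isolates any one of them.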